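From bromo to butoxy: an estimate for compound 4

The compounds below may be only part of what the source reports. "The series", "measured", "known", "first", "only" and "open" are said of these compounds alone.

Measured in a functional assay on MT4 cells (Homo sapiens) for cytotoxicity, read by MTT assay; a lower number here means that less compound is tolerated, a higher number that more compound is tolerated:
Compound 1 `Cc1c(O)nc(SCc2ccc(C#N)cc2)nc1Cc1c(Cl)cccc1Cl`: > 60000 nM, a limit of the assay and not a number
Compound 2 `Cc1c(O)nc(SCc2ccc(O)cc2)nc1Cc1c(Cl)cccc1Cl`: 41000 nM
Compound 3 `Cc1c(O)nc(SCc2ccc(Br)cc2)nc1Cc1c(Cl)cccc1Cl`: 13000 nM

Among the compounds with values here, of the two actual numbers, the one for compound 3 is the lower, with a 3.2-fold lower number from compound 2 to compound 3 (0.50 log units; beyond the scatter). Compound 1 offers only a limit, so no exact distance can be taken from it.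

Compound 4 `CCCCOc1ccc(CSc2nc(O)c(C)c(Cc3c(Cl)cccc3Cl)n2)cc1` has not yet been measured. It carries butoxy in place of bromo on an aromatic carbon, para to a large group: butoxy in place of bromo on an aromatic carbon.

The measured steps also exchange a single group on an aromatic carbon. The series shows an at least 4.6-fold lower number from compound 1 to compound 3 (0.66 log units; beyond the scatter), and it also shows an at least 1.4-fold lower number from compound 1 to compound 2 (0.16 log units; that floor lies within the scatter). None of these steps brings in butoxy, so they suggest a likely size but give no firm direction. Going by the modest 3.2-fold lower number from compound 2 to compound 3 (0.50 log units; beyond the scatter), a step of similar or smaller size is expected in this assay, leaning slightly towards a lower number and possibly staying within the scatter. The expected change is a 1.3-fold lower number from compound 3 to compound 4 (0.11 log units; within the scatter). For compound 4 the estimated value is 10000 nM, with an expected range from 3500 nM to 30000 nM.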

Compound 4, half-maximal cytotoxic concentration: 3100 nM
Beside the measured number, compound 4's estimate is 3.2-fold (0.51 log units) above it; the measured number lies below the stated range.
By their numbers in this assay, from the lowest: compound 4; then compound 3; then compound 2. At a limit, above all of these: compound 1.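

In this assay, butoxy at this place, on the aromatic carbon para to a large group, brings the series to a level that none of the earlier groups reached, with a 4.2-fold lower number from compound 3 to compound 4 (0.62 log units; beyond the scatter) as the step from the lowest number seen so far. Within the data shown here, the exchange at the oxygen is larger still, with a 13-fold lower number from compound 2 to compound 4 (1.12 log units; beyond the scatter) showing that adding a butyl to the hydroxy oxygen of compound 2 gives a large change, whereas the one step between two actual numbers among the earlier compounds was only modest. Compound 1 stands at a limit of the assay, so an at least 19-fold lower number from compound 1 to compound 4 (1.28 log units; beyond the scatter) gives only a floor for the real distance, and the limit itself reads: the limit of > 60000 nM in this assay, at which 1 of the 4 values shown sits.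

The compounds shown leave open whether the lower number follows the butyl chain or the oxygen that carries it, and how a shorter methoxy, a longer hexyloxy chain or a plain butyl would read at this place. They also leave open how an amine or a carboxylic acid would read there, and whether the order seen among these four compounds would hold for other groups.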